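The source may hold more compounds than are shown below. What is called first, only, known or untested is meant among the compounds shown, and "the series" means these compounds.

Compound 1 `c1cncc(-c2ccccc2OCC2=NCCN2)c1` gives 158 nM in a functional assay for activation of Alpha-1D adrenergic receptor (Homo sapiens), read by calcium flux; a lower number here means that less compound is needed, a higher number that more compound is needed for the effect. Compound 2 `c1ccc(-c2ccncn2)c(OCC2=NCCN2)c1` gives only a limit of the assay, < 100000 nM. Compound 3 `c1ccc(-c2ccsc2)c(OCC2=NCCN2)c1` gives 12.6 nM.

Compound 3 stands lowest of the two readable numbers; the nearest measured step is a 13-fold lower number from compound 1 to compound 3 (1.10 log units; beyond the scatter). The step that the limit leaves unreadable from compound 2 to compound 3 cannot be sized.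

Compound 4 `c1ccc(-c2ncc[nH]2)c(OCC2=NCCN2)c1` differs from compound 3 in one place: 1H-imidazol-2-yl in place of thiophen-3-yl on an aromatic carbon. Going by the values given here, the only readable step bearing on this swap is a 13-fold lower number from compound 1 to compound 3 (1.10 log units; beyond the scatter), where a ring holding nitrogen gave the higher number and thiophen-3-yl the lower. Exchanging thiophen-3-yl again for a nitrogen-bearing ring is therefore expected to move the number back up, roughly a 13-fold higher number from compound 3 to compound 4 (1.10 log units; beyond the scatter). Compound 4 is estimated at 160 nM, in a range from 30 nM to 900 nM.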

Compound 4, half-maximal effective concentration: < 100000 nM
Compound 4 was reported as a limit; the forecaster's own chance of this, stated with the estimate: 15%; the middle value is on the limit's open side.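

Going by these compounds alone, compound 4 gives only a limit, so no step to it from compound 1, compound 2 or compound 3 can be read: the limit of < 100000 nM in this assay, at which 2 of the 4 values shown sit. The compounds shown leave open where compound 2 and compound 4 truly lie relative to compound 1 and compound 3.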